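Phenethyl Replaces Fluorophenyl on the Chain of a Triazine

This account rests on a few compounds, and the source may have more. Where it says the series, first, only, none or still open, it means among the compounds named here.

Compound 3 `Nc1nc(NCc2ccc(F)cc2)nc(-c2c(F)cccc2CO)n1` stands second highest of the three compounds measured in a functional assay on cells for positive allosteric modulation of G-protein coupled receptor 68 (Homo sapiens), read by a luciferase reporter and cAMP accumulation, with a stated time of 30 min, at pH 6.8 and pH 8.3, in the presence of a further agent that is not named here (a lower number here means a less potent compound, a higher number a more potent compound, by a factor of ten per unit of this negative logarithm), giving 4.45; compound 2 `Nc1nc(NCc2ccccc2F)nc(-c2c(F)cccc2CO)n1` gives 4.22, and compound 1 `Nc1nc(NCCCc2ccccc2)nc(-c2ccccc2CO)n1` gives 5.22. The change to compound 4 `Nc1nc(NCCCc2ccccc2)nc(-c2c(F)cccc2CO)n1` is phenethyl in place of 4-fluorophenyl on a saturated chain carbon bound to a nitrogen on an aromatic ring. Within the data shown here, the only measured step at that chain carbon is a number 0.23 log units higher from compound 2 to compound 3 (within the scatter), a different swap that bears on it only loosely. Compound 1, which carries the same entering phenethyl group, gives 5.22, and this is the closest guide. Compound 4 is therefore expected to sit higher than compound 3, with an estimated step of a number 0.55 log units higher from compound 3 to compound 4 (beyond the scatter) in this assay. The estimate for compound 4 is 5, ranging from 4.4 to 5.6.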

Compound 4, negative logarithm of the antagonist equilibrium constant: 4.47
Estimate against measurement, compound 4: 0.53 log units above; low and high end bracket the measured number.
By their numbers in this assay, from the lowest: compounds 2, 3 and 4 (each within the scatter of the next); then compound 1.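

In this assay, phenethyl on the saturated chain carbon does not separate from either fluorophenyl group, with a number 0.02 log units higher from compound 3 to compound 4 (within the scatter) and with a number 0.25 log units higher from compound 2 to compound 4 (within the scatter) in the same reading. The step beyond the scatter lies instead at the aromatic carbon, where fluoro in place of hydrogen gives a number 0.75 log units lower from compound 1 to compound 4 (beyond the scatter) for the same phenethyl group. No measurement given here explains either result.

From the compounds shown here alone, only compound 1 and compound 4 read this fluoro change, so whether it holds with other chain groups stays open. Also open, going by these compounds, is what an amine, a carboxylic acid or a longer chain in place of phenethyl would give on that chain carbon.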